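Acetyl to dimethylamino on the pendant phenyl ring

This account rests on a few compounds, and the source may have more. Where it says the series, first, only, none or still open, it means among the compounds named here.

Measured compounds:
compound 1 `COc1cc(C)cc(-c2c(-c3ccnc(-c4ccc(C(C)=O)cc4)c3)cnn2CC#N)c1`: 2870 nM
compound 2 `COc1cc(C)cc(-c2nn(CC#N)cc2-c2ccnc(-c3ccc(N(C)C)cc3)c2)c1`: 253 nM

Going by the values given here, in a functional assay on NCI/ADR-RES cells (Homo sapiens) for inhibition, read by sulforhodamine B assay, with a stated time of 48 h (on this read-out higher numbers stand for weaker inhibition of growth and lower numbers for stronger inhibition of growth), compound 1 gives the highest of the two numbers, 2870 nM, while compound 2 gives 253 nM; the two compounds differ in more than one place, so their values show only that compound 2 sits well beyond the scatter below compound 1. Compound 3 `COc1cc(C)cc(-c2c(-c3ccnc(-c4ccc(N(C)C)cc4)c3)cnn2CC#N)c1` differs from compound 1 in one place: dimethylamino in place of acetyl on an aromatic carbon. Among the compounds with values here, no measured pair isolates this change. Given that compound 2, which carries the same dimethylamino group, gives 253 nM, a step downward beyond the scatter is expected, a 7.2-fold lower number from compound 1 to compound 3 (0.86 log units; beyond the scatter). For compound 3 the estimate is 400 nM, within 120 nM to 1500 nM.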

Compound 3, concentration for 50% growth inhibition: 47.9 nM
Compound 3: the middle estimate sits 8.4-fold (0.92 log units) above what was measured; measured number outside the range, below it.
By their numbers in this assay, from the lowest: compound 3; then compound 2; then compound 1.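

In this assay the change from 4-acetylphenyl to 4-(dimethylamino)phenyl gives a 60-fold lower number from compound 1 to compound 3 (1.78 log units; beyond the scatter) as a large step with all else held constant. The read-out at this place, para to a large group, therefore depends strongly on the group it carries, although both groups have the same counted heavy atoms and hydrogen-bond acceptors. Nothing on hand accounts for the size of this step.

From the compounds shown here alone, whether the step is specific to dimethylamino stays open. A primary amine, morpholine or a carboxylic acid at this place would help to answer that.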